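Furan to Bromothiophene on a Shared Aminothiophene Ketone

The compounds below may be only part of what the source reports. "The series", "measured", "known", "first", "only" and "open" are said of these compounds alone.

Compound 1, `CC(C)Nc1sc(C(=O)c2cccc(C#N)c2)c(N)c1C#N`: in an assay for inhibition of Maternal embryonic leucine zipper kinase (Homo sapiens), read by ADP-Glo, with a stated time of 0.5 h (on this read-out higher numbers stand for weaker inhibition and lower numbers for stronger inhibition), compound 1 reaches only the limit of > 5000 nM.
Compound 2, `CC(C)Nc1sc(C(=O)c2ccc(C#N)cc2)c(N)c1C#N`: in this assay compound 2 likewise reaches only the limit of > 5000 nM.
Compound 3, `CC(C)Nc1sc(C(=O)c2ccco2)c(N)c1C#N`: in this assay compound 3 gives 1350 nM.

Two of the three results are limits rather than numbers, as the limit of > 5000 nM in this assay, at which 2 of the 3 values shown sit, makes plain. For the measured compounds named here, compound 3 is therefore the only compound of the three with a numerical result in this assay, and it is the sole point of reference for anything further. Compounds 1 and 2 carry a nitrile-bearing phenyl on the carbonyl carbon, compound 3 a furan-2-yl; beyond that, the data allow no ordering between them.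

Compound 4, `CC(C)Nc1sc(C(=O)c2cc(Br)cs2)c(N)c1C#N`, differs from compound 3 in one place: 4-bromothiophen-2-yl in place of furan-2-yl on a carbonyl carbon. Going by the values given here, no step between measured compounds exists for a change of this kind, so there is no measured precedent to lean on. The expectation is a step that stays within the usual scatter, or at most a modest move toward stronger inhibition in this assay. The expected step is a 1.5-fold lower number from compound 3 to compound 4 (0.18 log units; within the scatter). Compound 4 is estimated at 900 nM, with a range from 300 nM to 4000 nM.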

Compound 4, half-maximal inhibitory concentration: 599 nM
Estimate against measurement, compound 4: 1.5-fold (0.18 log units) above, and the stated range covers the measured number.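

For the compounds shown here, the replacement of furan-2-yl by 4-bromothiophen-2-yl on a carbonyl carbon gives a 2.3-fold lower number from compound 3 to compound 4 (0.35 log units; beyond the scatter) in this assay and is the first change at this position that can be read as a step, with a number at both ends. Compound 1 and compound 2, which carry nitrile-bearing phenyl groups at the same place, each stop at a limit and give no number: the limit of > 5000 nM in this assay, at which 2 of the 4 values shown sit. The change replaces the ring and adds a bromine in a single move, and nothing shown gives a cause for the step or separates those two parts.

From the compounds shown here alone, it remains open whether the thiophene or the bromine accounts for the step, a question that a plain thiophen-2-yl or a 4-chlorothiophen-2-yl on the same carbonyl carbon could answer. The compounds shown also leave open how a longer chain in place of the isopropyl group on the amine of the shared core, or a carboxylic acid on the five-membered ring, would read in this assay.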